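Swapping Bromine for Iodine on the Outer Ring

The source may hold more compounds than are shown below. What is called first, only, known or untested is meant among the compounds shown, and "the series" means these compounds.

Of the compounds shown here, three sharing one core have been measured in an assay on CHO cells for displacement of a labelled ligand from adenosine receptor A1 (Homo sapiens), read by scintillation counting, with a stated time of 90 min, tested at 1 uM, in the presence of a further agent that is not named here; on this read-out lower numbers stand for less inhibition and higher numbers for more inhibition at the one concentration tested (going by the name of the read-out). Compound 1 `CCCn1c(=O)[nH]c2nc(-c3ccc(S(=O)(=O)N4CCN(c5ccccc5Br)CC4)cc3)[nH]c2c1=O` gives 28%. Compound 2 `CCCn1c(=O)[nH]c2nc(-c3ccc(S(=O)(=O)N4CCN(c5cccc(F)c5)CC4)cc3)[nH]c2c1=O` gives 34%. Compound 3 `CCCn1c(=O)[nH]c2nc(-c3ccc(S(=O)(=O)N4CCN(c5ccc(Br)cc5)CC4)cc3)[nH]c2c1=O` gives 13%, the lowest of the three: the steps leading to it are a number 15 percentage points lower from compound 1 to compound 3 (beyond the scatter) and a number 21 percentage points lower from compound 2 to compound 3 (beyond the scatter). Between the other two, the step is a number 6 percentage points higher from compound 1 to compound 2 (within the scatter). So compound 3, which carries the 4-bromophenyl group, shows the least inhibition of the three, and both steps that reach it point downward beyond the scatter.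

Compound 4 `CCCn1c(=O)[nH]c2nc(-c3ccc(S(=O)(=O)N4CCN(c5ccc(I)cc5)CC4)cc3)[nH]c2c1=O` differs from compound 3 in one place: iodo in place of bromo on an aromatic carbon. Going by the values given here, none of the measured steps exchanges one halogen for another; each of them swaps the whole group on the amine nitrogen in the ring. They therefore give no direct guidance on the size of this step. What they do show is that compound 3 sits at the low end, and the exchange of bromo for iodo alters nothing in what has been counted. The step of a number 1 percentage points higher from compound 3 to compound 4 (within the scatter) is expected to be small, within the scatter, with no clear direction. The estimate for compound 4 in this assay is 14%, with a range from 2% to 30%.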

Compound 4, a percentage reported as inhibition, at one concentration (the size of the read-out at that concentration, not a potency): 24%
Beside the measured number, compound 4's estimate is 10 percentage points below it, within the range that was stated.
By their numbers in this assay, from the lowest: compound 3; then compounds 4, 1 and 2 (each within the scatter of the next).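

Exchanging one halogen for another at this place, on an aromatic carbon para to a large group, is enough to shift the result in this assay: the change from bromo to iodo gives a number 11 percentage points higher from compound 3 to compound 4 (beyond the scatter) even though one heavy atom replaces one heavy atom, with no change in the counted hydrogen-bond donors, acceptors or net charge. The change also alters how this compound compares with the other two, since compound 3 stood clearly apart from both, whereas the 4-iodophenyl group now gives a number 10 percentage points lower from compound 2 to compound 4 (within the scatter) and a number 4 percentage points lower from compound 1 to compound 4 (within the scatter) and so cannot be told apart from the 3-fluorophenyl or 2-bromophenyl groups. Nothing available here explains why this one-atom exchange moves the number.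

Still open, as far as these compounds go, is whether chloro or a non-halogen group such as methoxy or nitrile at this same place would give a number closer to that of the bromo compound or the iodo compound. From the compounds shown here alone, it is also open whether iodo would give a similar step on the 2-bromophenyl or 3-fluorophenyl ring, where the group sits elsewhere on the ring.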